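The compounds below may be only part of what the source reports. "The series", "measured", "known", "first", "only" and "open" are said of these compounds alone.

Measured so far in an ADME assay on MT4 cells (Homo sapiens) for cytotoxicity, read by MTT assay, with a stated time of 4 days; on this read-out lower numbers stand for higher toxicity in this test and higher numbers for lower toxicity in this test:
compound 1 `O=C(COc1cccc2ccccc12)N/N=C/c1cccc([N+](=O)[O-])c1` — 12.1 ug/mL
compound 2 `O=C(COc1cccc2ccccc12)N/N=C/c1cccc(O)c1` — 32.6 ug/mL
compound 3 `C/C(=N\NC(=O)COc1cccc2ccccc12)c1ccccc1O` — 11.3 ug/mL

Compound 2 stands highest of the three in this assay, with compound 1 nearest and compound 3 furthest, both beyond the scatter. Compound 4 `COc1ccc(/C=N/NC(=O)COc2cccc3ccccc23)cc1` is not yet measured. Its difference from compound 2 is 4-methoxyphenyl in place of 3-hydroxyphenyl on a carbon with a double bond to nitrogen. Within the data shown here, the only measured step, a 2.7-fold higher number from compound 1 to compound 2 (0.43 log units; beyond the scatter), concerns a different exchange at the same position, so no measured step bears directly on this change; it only shows that the group on that carbon can shift the number modestly. Compound 4 is therefore expected to lie near compound 2, with a small downward lean toward compounds 1 and 3, as a 1.6-fold lower number from compound 2 to compound 4 (0.21 log units; within the scatter). The estimate for compound 4 is 20 ug/mL, ranging from 8 ug/mL to 50 ug/mL.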

Compound 4, half-maximal cytotoxic concentration: 76.9 ug/mL
For compound 4 the middle estimate is 3.8-fold (0.58 log units) below the measured one, and the stated range ends below it.
By their numbers in this assay, from the lowest: compounds 3 and 1 (each within the scatter of the next); then compound 2; then compound 4.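

In this assay, 4-methoxyphenyl in place of 3-hydroxyphenyl on a carbon with a double bond to nitrogen gives a 2.4-fold higher number from compound 2 to compound 4 (0.37 log units; beyond the scatter). This shows that compound 2 does not mark the top of the range at this position, and that a group with no hydrogen-bond donor can go with a higher number than one with a donor. Nothing shown accounts for the step.

Because the group and its place on the ring change together, their shares remain unseparated. On these data alone, how 4-hydroxyphenyl, 3-methoxyphenyl or an amine on that ring would read stays open.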